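Phosphate in place of a methyl on a beta-lactam

The compounds below may be only part of what the source reports. "The series", "measured", "known", "first", "only" and "open" are said of these compounds alone.

Of the compounds shown here, two of a shared core have been measured. Compound 1 `COc1ccc([C@@H]2[C@H](Oc3ccccc3)C(=O)N2c2cc(OC)c(OC)c(OC)c2)cc1OC` carries a 3,4-dimethoxyphenyl on a saturated ring carbon; in a functional assay on MCF7 cells (Homo sapiens) for antiproliferative activity, read by MTT assay, with stated times of 24 h and 72 h (a lower number here means a stronger inhibitor, a higher number a weaker inhibitor), compound 1 gives 26000 nM, the highest of the two numbers. Compound 2 `COc1cc(N2C(=O)[C@@H](Oc3ccccc3)[C@H]2c2ccc(SC)cc2)cc(OC)c1OC`, with 4-(methylsulfanyl)phenyl in that place, gives 7700 nM in this assay. Within the data shown here, the one measured step, a 3.4-fold lower number from compound 1 to compound 2 (0.53 log units; beyond the scatter), shows that changing the aryl group on the saturated ring carbon shifts the number by a modest amount.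

Compound 3 `COc1ccc([C@@H]2[C@H](Oc3ccccc3)C(=O)N2c2cc(OC)c(OC)c(OC)c2)cc1OP(=O)(O)O` differs from compound 1 elsewhere: a group of 4 heavy atoms (3 oxygen, 1 phosphorus; no ring) in place of one carbon atom, on an oxygen on an aromatic ring. Among the measured compounds shown here, no measured step touches this oxygen, so the step from compound 1 to compound 2 bears on it only as a sign of how far one change on this core has moved the number so far. The expectation is therefore a shift of similar size, with a lower number judged somewhat more likely than a higher one, and the step is estimated as a 2.2-fold lower number from compound 1 to compound 3 (0.34 log units; beyond the scatter). For compound 3 the estimate in this assay is 12000 nM, within a range from 2500 nM to 60000 nM.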

Compound 3, half-maximal inhibitory concentration: 42000 nM
Estimate against measurement, compound 3: 3.5-fold (0.54 log units) below; measured number inside the range.
By their numbers in this assay, from the lowest: compound 2; then compounds 1 and 3 (each within the scatter of the next).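

At this oxygen on an aromatic ring, replacing the methyl with the group of 4 heavy atoms (3 oxygen, 1 phosphorus) gives a 1.6-fold higher number from compound 1 to compound 3 (0.21 log units; within the scatter) in this assay, so the two compounds cannot be told apart in this read-out. Among these compounds, this is the first information on this position, and it shows that a single methyl can give way to a much larger group, one with 2 hydrogen-bond donors where the methyl has none, without a change beyond the usual scatter. Nothing available here explains why the number stays within the scatter after so large a change in structure.

As far as these compounds go, what remains open is whether this position is equally indifferent to other groups in place of the methyl, such as a longer chain like propyl, a carboxylic acid or an amine, any of which could show whether some replacement moves the number beyond the scatter. From the compounds shown here alone, it is also open whether the same swap would behave alike on the core of compound 2, which carries 4-(methylsulfanyl)phenyl on the saturated ring carbon instead of 3,4-dimethoxyphenyl.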